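This account rests on a few compounds, and the source may have more. Where it says the series, first, only, none or still open, it means among the compounds named here.

Measured so far:
- compound 1 `COc1ccc(S(=O)(=O)Oc2ccccc2/C=C(\C#N)C(=O)Nc2nnc(Cc3cccc4ccccc34)s2)cc1` gives 98%
- compound 2 `N#C/C(=C\c1ccccc1OS(=O)(=O)c1ccccc1[N+](=O)[O-])C(=O)Nc1nnc(Cc2cccc3ccccc23)s1` gives 23%

In a functional assay on HL-60 cells (Homo sapiens) for inhibition, read by CCK-8 assay, with a stated time of 48 h, tested at 20 uM (on this read-out higher numbers stand for more inhibition of growth at the one concentration tested and lower numbers for less inhibition of growth), compound 2 stands at 23%, the lower of the two numbers. Compound 3 `N#C/C(=C\c1ccccc1OS(=O)(=O)c1ccc(Cl)cc1)C(=O)Nc1nnc(Cc2cccc3ccccc23)s1` differs from it in one place: 4-chlorophenyl in place of 2-nitrophenyl on a sulfonyl sulfur. For the measured compounds named here, only one measured step bears on this place, and it was large and beyond the scatter: a number 75 percentage points lower from compound 1 to compound 2 (beyond the scatter). One step is thin evidence, but a large upward move is expected, probably not all the way back to compound 1. The expected change is a number 47 percentage points higher from compound 2 to compound 3 (beyond the scatter). For compound 3 the estimated value is 70%, with an expected range from 35% to 100%.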

Compound 3, percent growth inhibition at one concentration: 15%
For compound 3 the middle estimate is 55 percentage points above the measured one; measured number below the stated range.
By their numbers in this assay, from the lowest: compounds 3 and 2 (each within the scatter of the next); then compound 1.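

In this assay the change to 4-chlorophenyl from 2-nitrophenyl on the sulfonyl sulfur gives a number 8 percentage points lower from compound 2 to compound 3 (within the scatter) and so leaves the two groups indistinguishable here. Replacing methoxy with chloro on an aromatic carbon gives a number 83 percentage points lower from compound 1 to compound 3 (beyond the scatter) and shows that the low inhibition is not peculiar to the 2-nitrophenyl group, since among these three compounds only the 4-methoxyphenyl group of compound 1 goes with high inhibition. Nothing available explains this difference.

Going by these compounds, whether a hydroxy, ethoxy or dimethylamino group in place of methoxy on the aromatic carbon would keep the inhibition of compound 1 stays open.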